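Shifting the nitroimidazole of compound 1 without changing its atoms

This account rests on a few compounds, and the source may have more. Where it says the series, first, only, none or still open, it means among the compounds named here.

Compound 1 `COc1cc2ncnc(Nc3ccc(F)c(Cl)c3)c2cc1OCCCCn1ccnc1[N+](=O)[O-]` gives 2210 nM in a functional assay on HT-29 cells (Homo sapiens) for cytotoxicity, read by sulforhodamine B assay, with a stated time of 72 h (on this read-out higher numbers stand for weaker inhibition and lower numbers for stronger inhibition), the lowest of the two numbers shown. Compound 2 `C#Cc1cccc(Nc2ncnc3cc(OC)c(OCCCCn4ccnc4[N+](=O)[O-])cc23)c1` gives 10100 nM, and the step of a 4.6-fold higher number from compound 1 to compound 2 (0.66 log units; beyond the scatter) lies at a different part of the molecule. Compound 3 `COc1cc2ncnc(Nc3ccc(F)c(Cl)c3)c2cc1OCCCn1c([N+](=O)[O-])cnc1C` has not been measured; it differs from compound 1 by 2-methyl-5-nitro-1H-imidazol-1-yl in place of (2-nitro-1H-imidazol-1-yl)methyl on a saturated chain carbon, three bonds along the chain from an oxygen on an aromatic ring. Within the data shown here, no measured step touches this nitroimidazole unit, so the outcome is uncertain, and a change of a 1.4-fold higher number from compound 1 to compound 3 (0.13 log units; within the scatter) is expected, meaning essentially none beyond the scatter. Compound 3 is therefore estimated at 3000 nM, within a range from 900 nM to 10000 nM.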

Compound 3, half-maximal inhibitory concentration: 23200 nM
The estimate for compound 3 lay 7.7-fold (0.89 log units) below the measured number; measured number above the stated range.
By their numbers in this assay, from the lowest: compound 1; then compound 2; then compound 3.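

With the same atoms joined differently, 2-methyl-5-nitro-1H-imidazol-1-yl in place of (2-nitro-1H-imidazol-1-yl)methyl gives a 10-fold higher number from compound 1 to compound 3 (1.02 log units; beyond the scatter) in this assay. The arrangement of the side-chain end therefore matters here, even though neither its atom count nor its make-up changes, which the earlier step at a different part of the molecule could not show. No measurement shown accounts for this step.

The compounds shown leave open which part of the change counts: the shorter chain, the added methyl or the shifted nitro group. As far as these compounds go, how an amine in place of the nitroimidazole unit would fare also remains open.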